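Acyl Swap on a Pyrazoline Amide Nitrogen

The compounds below may be only part of what the source reports. "The series", "measured", "known", "first", "only" and "open" are said of these compounds alone.

Measured compounds and their values:
- Compound 1, `CN(C)c1ccc(C2CC(c3ccc(-n4ccnc4)cc3)=NN2)cc1`: 0.1%
- Compound 2, `CC(=O)N1N=C(c2ccc(N3CCN(C)CC3)cc2)CC1c1ccc(N(C)C)cc1`: -1.9%
- Compound 3, `COC(=O)CC(=O)N1N=C(c2ccc(N3CCN(C)CC3)cc2)CC1c1ccc(N(C)C)cc1`: -2.2%

All three compounds were tested in a functional assay on NCI-H1975 cells (Homo sapiens) for inhibition, read by sulforhodamine B assay, tested at 10 uM; a lower number here means less inhibition, a higher number more inhibition at the concentration tested (going by the name of the read-out). None of them shows appreciable inhibition, and compound 3 is not separated from either neighbour: its number lies within the scatter of compound 2 and of compound 1.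

Among the measured compounds shown here, the one step among the measured compounds that changes a single place is a number 0.3 percentage points lower from compound 2 to compound 3 (within the scatter), a change on the acyl group attached to the amide-type nitrogen in the ring, and it is within the scatter.

Compound 4, `CN1CCN(c2ccc(C3=NN(C(=O)c4ccc(C(F)(F)F)cc4)C(c4ccc(N(C)C)cc4)C3)cc2)CC1`, has not yet been measured. It differs from compound 3 at the same acyl group: 4-(trifluoromethyl)phenyl in place of (methoxycarbonyl)methyl on a carbonyl carbon. For the measured compounds named here, since the only comparable step, from compound 2 to compound 3, left the read-out unchanged, no step beyond the scatter is expected here; the expected change is a number 2.2 percentage points higher from compound 3 to compound 4 (within the scatter).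

Compound 4 is therefore estimated to give 0% in this assay, with a range from -10% to 10%.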

Compound 4, a percentage reported as inhibition, at one concentration (the size of the read-out at that concentration, not a potency): 93.2%
Compound 4: the middle estimate sits 93.2 percentage points below what was measured; measured number outside the range, above it.
By their numbers in this assay, from the lowest: compounds 3, 2 and 1 (each within the scatter of the next); then compound 4.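

Changing the acyl group on the amide-type ring nitrogen can decide the outcome in this assay: the change gives a number 95.4 percentage points higher from compound 3 to compound 4 (beyond the scatter) when 4-(trifluoromethyl)phenyl replaces (methoxycarbonyl)methyl on the carbonyl carbon, and a number 95.1 percentage points higher from compound 2 to compound 4 (beyond the scatter) when it replaces methyl. The earlier step of a number 0.3 percentage points lower from compound 2 to compound 3 (within the scatter) therefore described only those two groups, which have no ring, and not the position as a whole. Nothing available explains why this group has so large an effect.

On these data alone, it remains open whether the aromatic ring alone is enough or the trifluoromethyl on it is also needed, a question that a plain phenyl or a pyridine ring on the same carbonyl carbon would help to answer. A reading at a single concentration also leaves open how potent compound 4 is.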